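Fluorine in Place of Methyl on the Phenyl Ring

This account rests on a few compounds, and the source may have more. Where it says the series, first, only, none or still open, it means among the compounds named here.

In a functional assay on HepG2 cells (Homo sapiens) for antiproliferative activity, read by MTT assay, with a stated time of 24 h (on this read-out higher numbers stand for weaker inhibition and lower numbers for stronger inhibition), compound 1, `O=c1[nH]cc(S(=O)(=O)Nc2cccc(-c3cn(-c4ccccc4)nn3)c2)c(=O)[nH]1`, gives 11200 nM. Compound 2, `Cc1cccc(-n2cc(-c3cccc(NS(=O)(=O)c4c[nH]c(=O)[nH]c4=O)c3)nn2)c1`, gives 7050 nM in this assay. For compound 3, `Cc1ccc(-n2cc(-c3cccc(NS(=O)(=O)c4c[nH]c(=O)[nH]c4=O)c3)nn2)cc1`, this assay returns only a limit of > 20000 nM rather than a number, as noted in the survey of measured values (the limit of > 20000 nM in this assay, at which 1 of the 3 values shown sits). Thus compound 3 stands at the weak end of the three measured compounds: the step of an at least 1.7-fold higher number from compound 1 to compound 3 (0.25 log units; that floor lies within the scatter) and the step of an at least 2.8-fold higher number from compound 2 to compound 3 (0.45 log units; beyond the scatter) both point to a higher number for compound 3.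

Compound 4, `O=c1[nH]cc(S(=O)(=O)Nc2cccc(-c3cn(-c4ccc(F)cc4)nn3)c2)c(=O)[nH]1`, differs from compound 3 by fluoro in place of methyl on an aromatic carbon, on an aromatic carbon of a six-membered aromatic ring of carbon only, para to a large group; cut one bond further out, the change reads 4-methylphenyl to 4-fluorophenyl. Among the measured compounds shown here, none of the measured steps swaps fluoro for methyl. The closest step, an at least 1.7-fold higher number from compound 1 to compound 3 (0.25 log units; that floor lies within the scatter), shows that placing the methyl at this position moved the number up, but only by a floor within the scatter, so the effect of removing it again is uncertain. Compound 4 is therefore expected to land near compound 3 or compound 1, with a step of an at least 1.3-fold lower number from compound 3 to compound 4 (0.12 log units; that floor lies within the scatter) that is estimated not to exceed the scatter. The estimate for compound 4 in this assay is 15000 nM, ranging from 6000 nM to 40000 nM.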

Compound 4, half-maximal inhibitory concentration: > 20000 nM
Compound 4: no number, only a limit; the forecaster's own chance of this, stated with the estimate: 40%; at least 1.3-fold (0.12 log units) between middle value and limit.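

In this assay compound 4 returns only a limit and no number, and compound 3 sits at that same limit: the limit of > 20000 nM in this assay, at which 2 of the 4 values shown sit.

With a limit at both ends, the step for fluoro in place of methyl cannot be read, so the two groups cannot be ranked against each other at this place, para to a large group. What the new compound adds is that a second group here also ends at the limit, with an at least 2.8-fold higher number from compound 2 to compound 4 (0.45 log units; beyond the scatter) and an at least 1.7-fold higher number from compound 1 to compound 4 (0.25 log units; that floor lies within the scatter); only the first of these floors clears the scatter, so the 4-fluorophenyl is separated from the 3-methylphenyl but not from the unsubstituted phenyl.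

The compounds shown leave open how far the number lies past the limit for either compound, and so whether methyl and fluoro differ here at all. They also leave open what an amine or a carboxylic acid would do at this place, and whether fluoro would give a readable number at the place the methyl holds in compound 2.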